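Notes on the step from compound 3 to compound 4

This account rests on a few compounds, and the source may have more. Where it says the series, first, only, none or still open, it means among the compounds named here.

Three compounds of the series are on hand, together with one not yet tested. In an assay on COS-7 cells for agonist activity at Free fatty acid receptor 1 (Homo sapiens), read by scintillation counting and inositol phosphate accumulation, with a stated time of 90 min (on this read-out lower numbers stand for an effect already at smaller amounts and higher numbers for an effect only at larger amounts of compound), compound 1 `Cc1cc(=O)oc2cc(OCc3nc(N)nc(Nc4ccc(O)cc4)n3)ccc12` has the entry "not determined" (no result reported), no numerical result. In this assay compound 2 `Cc1ccc(Nc2nc(N)nc(COc3ccc4c(c3)CCC(C)(C)O4)n2)cc1` likewise has the entry "not determined" (no result reported), no numerical result. Among the compounds with values here, compound 3 `Cc1ccc(Nc2nc(N)nc(COc3cccc(N4CCCC4=O)c3)n2)cc1Cl` therefore carries the only number: in this assay compound 3 gives 820 nM. Within the data shown here, since the other two entries hold no value, compound 3 cannot be placed against anything else, and no step between measured compounds can be drawn.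

Compound 4 `Cc1ccc(Nc2nc(N)nc(COc3cccc(N4CCCS4(=O)=O)c3)n2)cc1Cl` is the next compound to be tested. It differs from compound 3 in one place: a group of 7 heavy atoms (3 carbon, 1 nitrogen, 2 oxygen, 1 sulfur; one five-membered non-aromatic ring with 2 hetero atoms) in place of a group of 6 heavy atoms (4 carbon, 1 nitrogen, 1 oxygen; one five-membered non-aromatic ring with 1 hetero atom), on an aromatic carbon. The 2-oxopyrrolidin-1-yl group leaves, and the entering group, which has no common name, is one five-membered non-aromatic ring with 2 hetero atoms, sitting on an aromatic carbon of a six-membered aromatic ring of carbon only, meta to a large group.

With no comparable step shown among measured compounds, nothing in the data sets a direction for this change. The step in this assay is expected to be a 1.2-fold higher number from compound 3 to compound 4 (0.09 log units; within the scatter), a shift that stays inside the usual scatter rather than a real move. In this assay compound 4 is therefore estimated at 1000 nM, with a range from 300 nM to 3500 nM.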

Compound 4, half-maximal effective concentration: 9700 nM
The estimate for compound 4 lay 9.7-fold (0.99 log units) below the measured number; measured number above the stated range.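

In this assay, within the data shown here, a 12-fold higher number from compound 3 to compound 4 (1.07 log units; beyond the scatter) is the first step that can be read, and it shows that the group on this aromatic carbon, meta to a large group, is not interchangeable among five-membered non-aromatic rings. Exchanging 2-oxopyrrolidin-1-yl for the entering ring, with 7 heavy atoms against 6, a sulfur, and 2 hydrogen-bond acceptors against 1, moves the result well beyond the scatter and towards an effect only at larger amounts of compound. No measurement at hand bears on which of these differences accounts for the step.

The values of compound 1 and compound 2 are absent, so no other step can be read, and this single pair sets no pattern for the rest of the series. Open, as far as these compounds go, is whether a smaller group at the same place, such as a primary amine, a carboxylic acid or an open-chain acetamide, would give a lower number than compound 3 does, and whether the same exchange would have a step of like size on the other side of the shared core.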